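Changing the Aryl Group on the Sulfonyl of Compound 3

The source may hold more compounds than are shown below. What is called first, only, known or untested is meant among the compounds shown, and "the series" means these compounds.

The measured compounds:
Compound 1 `COc1ccc(-c2cc(=O)c3c(OC)cc(OC)cc3n2Cc2ccccc2)cc1` gives > 17300 nM in a functional assay on HepG2 cells (Homo sapiens) for antiproliferative activity, with a stated time of 72 h; on this read-out lower numbers stand for an effect already at smaller amounts and higher numbers for an effect only at larger amounts of compound; this value is a limit of the assay.
Compound 2 `COC(=O)c1cc(=O)c2c(OC)cc(OC)cc2n1C` gives > 19000 nM in this assay; this value is a limit.
Compound 3 `COc1ccc(-c2cc(=O)c3c(OC)cc(OC)cc3n2S(=O)(=O)c2ccc([N+](=O)[O-])cc2)cc1` gives > 29300 nM in this assay; this value is a limit.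

Compound 3 stands at a limit of this assay, as the evidence the limit of > 29300 nM in this assay, at which 1 of the 3 values shown sits, states, and the other two measured compounds likewise sit at limits, the limit of > 17300 nM in this assay, at which 1 of the 3 values shown sits, and (the limit of > 19000 nM in this assay, at which 1 of the 3 values shown sits). No measured step connects any pair of these compounds. Compound 4 `COc1ccc(-c2cc(=O)c3c(OC)cc(OC)cc3n2S(=O)(=O)c2cc(Cl)cc(Cl)c2O)cc1` differs from compound 3 by one change: 3,5-dichloro-2-hydroxyphenyl in place of 4-nitrophenyl on a sulfonyl sulfur. Since compound 3 shows no numbered effect within the tested range, the step from compound 3 to compound 4 is expected to stay within the scatter, a step that the limit leaves unreadable from compound 3 to compound 4, with no direction claimed. Compound 4 is therefore expected to give about 30000 nM in this assay, most likely again reported as a limit, between 8000 nM and 100000 nM.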

Compound 4, half-maximal effective concentration: > 37900 nM
Compound 4 gave a limit, no number (the forecaster's own chance of this, stated with the estimate: 75%); middle value at least 1.2-fold (0.10 log units) away from the limit.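

In this assay compound 4 gives > 37900 nM, which is a limit, and compound 3 also stands at a limit, so the step between compound 3 and compound 4 cannot be read. The compounds shown leave open whether any aryl group on the sulfonyl sulfur gives a numbered effect in this assay.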